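From 4-methoxybenzyl to 4-methylbenzyl: working notes

This account rests on a few compounds, and the source may have more. Where it says the series, first, only, none or still open, it means among the compounds named here.

In an ADME assay on GES1 cells (Homo sapiens) for inhibition, read by MTT assay, with a stated time of 72 h (a higher number here means a weaker inhibitor, a lower number a stronger inhibitor), compound 1 `Cc1cc(Nc2ccn(Cc3ccccc3)n2)n2nc(SCc3ccc(Br)cc3)nc2n1` gives 44400 nM. In the same assay, compound 2 `Cc1cc(Nc2ccn(Cc3csc4ccc(Cl)cc34)n2)n2nc(SCc3ccc(Br)cc3)nc2n1` gives 31400 nM, and a 1.4-fold lower number from compound 1 to compound 2 (0.15 log units; within the scatter) stays within the scatter.

Compound 3 `COc1ccc(Cn2ccc(Nc3cc(C)nc4nc(SCc5ccc(Br)cc5)nn34)n2)cc1` reads > 50000 nM, which is a limit of this assay and not a number.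

Compound 4 `Cc1ccc(Cn2ccc(Nc3cc(C)nc4nc(SCc5ccc(Br)cc5)nn34)n2)cc1` carries methyl in place of methoxy on an aromatic carbon, para to a large group: methyl in place of methoxy on an aromatic carbon. Among the measured compounds shown here, two measured steps bear most directly on this change. The first, which places methoxy on that carbon, is an at least 1.1-fold higher number from compound 1 to compound 3 (0.05 log units; that floor lies within the scatter). The second, which exchanges the whole group on the saturated chain carbon, is an at least 1.5-fold higher number from compound 2 to compound 3 (0.20 log units; that floor lies within the scatter). For the measured compounds named here, the floors of both steps lie within the scatter, as does the only step between two exact values, so no step beyond the scatter is expected in this assay, and neither direction is favoured. The estimated step is an at least 1.1-fold lower number from compound 3 to compound 4 (0.04 log units; that floor lies within the scatter). Compound 4 is expected at 45000 nM, with an estimated range of 25000 nM to 75000 nM.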

Compound 4, half-maximal inhibitory concentration: > 50000 nM
Compound 4 gave a limit, no number (the forecaster's own chance of this, stated with the estimate: 40%); middle value at least 1.1-fold (0.04 log units) away from the limit.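

In this assay compound 4 gives a limit and not a number, the same limit as compound 3, so the step between these two compounds cannot be read: the limit of > 50000 nM in this assay, at which 2 of the 4 values shown sit.

Against the two compounds with exact values, the readings are an at least 1.1-fold higher number from compound 1 to compound 4 (0.05 log units; that floor lies within the scatter) and an at least 1.5-fold higher number from compound 2 to compound 4 (0.20 log units; that floor lies within the scatter). At this position methoxy is therefore not alone at the limit: methyl, which has no oxygen and no hydrogen-bond acceptor, sits there as well.

The order of methyl and methoxy stays open, as neither group has an exact value at this position in the compounds shown. Also open, going by these compounds, is whether an amine or a carboxylic acid on this aromatic carbon would give a number rather than a limit.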